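The source may report more compounds than this note shows. Statements on the series, on what has been measured and on what is new or still open speak of the compounds shown alone.

Measured so far in a functional assay on HCT-116 cells (Homo sapiens) for cytotoxicity, read by MTT assay, with a stated time of 72 h; on this read-out higher numbers stand for weaker inhibition and lower numbers for stronger inhibition:
- compound 1 `CN1[C@@H]2c3[nH]c4ccccc4c3C[C@H]1[C@H](C#N)N1[C@@H](CNC(=O)c3cccc(C(F)(F)F)c3)c3[nH]c4ccccc4c3C[C@@H]21` gives 630 nM
- compound 2 `CCc1ccc(C(=O)NC[C@H]2c3[nH]c4ccccc4c3C[C@H]3[C@H]4c5[nH]c6ccccc6c5C[C@@H]([C@H](C#N)N23)N4C)cc1` gives 100 nM

Within the data shown here, compound 2 has the lowest number of the two in this assay; its nearest neighbour is compound 1, separated by the step of a 6.3-fold lower number from compound 1 to compound 2 (0.80 log units; beyond the scatter), which is the only measured step and the only one that bears on an exchange of the aryl group on the carbonyl carbon.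

Compound 3 `CN1[C@@H]2c3[nH]c4ccccc4c3C[C@H]1[C@H](C#N)N1[C@@H](CNC(=O)c3ccc4ccccc4n3)c3[nH]c4ccccc4c3C[C@@H]21` differs from compound 2 as follows: quinolin-2-yl in place of 4-ethylphenyl on a carbonyl carbon. Among the measured compounds shown here, this is again an exchange of the aryl group on the carbonyl carbon, so the measured step from compound 1 to compound 2 is the only guide to its size; the direction of that step cannot be carried over, as quinolin-2-yl is not part of any measured pair. The step of a 3.0-fold higher number from compound 2 to compound 3 (0.48 log units; beyond the scatter) is therefore set as an expectation of a modest move with wide uncertainty, leaning towards a higher number given that compound 2 already sits at the lowest number seen.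

For compound 3 the expected value in this assay is 300 nM, with a range from 80 nM to 1200 nM.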

Compound 3, half-maximal inhibitory concentration: 240 nM
Beside the measured number, compound 3's estimate is 1.3-fold (0.10 log units) above it; low and high end bracket the measured number.
By their numbers in this assay, from the lowest: compound 2; then compound 3; then compound 1.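

In this assay, among these compounds, quinolin-2-yl is the only group on the carbonyl carbon so far with a ring holding a hetero atom and with a hydrogen-bond acceptor; the position tolerates it, with a 2.4-fold higher number from compound 2 to compound 3 (0.38 log units; beyond the scatter) against 4-ethylphenyl and a 2.6-fold lower number from compound 1 to compound 3 (0.42 log units; beyond the scatter) against 3-(trifluoromethyl)phenyl. The three aryl groups therefore form an order at this position, from compound 2 through compound 3 to compound 1, and all three steps among them lie beyond the scatter, so the exchange of this group alone moves the number in each pair. Nothing at hand accounts for this order.

Each exchange replaces the whole aryl group, so the contributions of the ethyl group, the trifluoromethyl group and the ring nitrogen of quinolin-2-yl cannot be separated from one another. As far as these compounds go, how a plain phenyl, a naphthalen-2-yl, or a phenyl carrying an amine or a carboxylic acid would fall in this order remains open.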